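Swapping Cyano for Chloro on the Benzyl Group

The source may hold more compounds than are shown below. What is called first, only, known or untested is meant among the compounds shown, and "the series" means these compounds.

In a functional assay on B16 cells (Mus musculus) for antiproliferative activity, read by MTT assay, with a stated time of 24 h (a lower number here means a stronger inhibitor, a higher number a weaker inhibitor), compound 1 (`COc1cccc(C(=O)Oc2ccc3c(=O)c(-c4cc(OC)c(OC)cc4OC)coc3c2)c1`) reads > 10000 nM, which is a limit of the assay and not a number. Within the data shown here, compound 2 (`COc1cc(OC)c(-c2coc3cc(OCc4ccc(C#N)cc4)ccc3c2=O)cc1OC`) gives 7000 nM, the only actual number available so far. Compound 3 (`COc1cc(OC)c(-c2coc3cc(OCc4ccc(Cl)cc4)ccc3c2=O)cc1OC`) carries a 4-chlorobenzyl in place of the 4-cyanobenzyl, with chloro in place of cyano on an aromatic carbon, para to a large group: chloro in place of cyano on an aromatic carbon. Among the measured compounds shown here, only one measured step lies near this change, an at least 1.4-fold lower number from compound 1 to compound 2 (0.15 log units; that floor lies within the scatter). It exchanges the whole group on the oxygen, and its floor lies within the scatter, so it gives no measured size for this smaller exchange. In this assay, the expected change is none beyond the scatter, a 1.1-fold lower number from compound 2 to compound 3 (0.03 log units; within the scatter). The estimate for compound 3 is 6500 nM, with an expected range from 2500 nM to 15000 nM.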

Compound 3, half-maximal inhibitory concentration: 2400 nM
Compound 3: the middle estimate sits 2.7-fold (0.43 log units) above what was measured; the whole stated range lies above it.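

Chloro in place of cyano on an aromatic carbon, para to a large group, gives a 2.9-fold lower number from compound 2 to compound 3 (0.46 log units; beyond the scatter) in this assay, so this small exchange on the benzyl group moves the reading beyond the scatter. The exchange of the whole group on the oxygen now also gives a step beyond the scatter, an at least 4.1-fold lower number from compound 1 to compound 3 (0.61 log units; beyond the scatter), which the earlier step with the 4-cyanobenzyl did not. That step is a floor and not a full size, because compound 1 stands at a limit of the assay and not at a number: the limit of > 10000 nM in this assay, at which 1 of the 3 values shown sits.

The compounds shown hold only cyano and chloro at this place, so it stays open whether bromo, methyl, methoxy or an amine there would read like chloro. From the compounds shown here alone, it also stays open whether chloro would give a similar step elsewhere on the benzyl ring.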